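The source may hold more compounds than are shown below. What is called first, only, known or untested is meant among the compounds shown, and "the series" means these compounds.

In a functional assay on A549 cells (Homo sapiens) for antiproliferative activity, read by MTT assay, with a stated time of 72 h (a lower number here means a stronger inhibitor, a higher number a weaker inhibitor), compound 1 `O=C1COc2ccc(-c3cccc(NS(=O)(=O)c4ccc(F)cc4)c3)cc2N1c1ccccc1` gives only the assay limit, > 40000 nM. Compound 2 `Cc1ccc(N2C(=O)COc3ccc(-c4cnc5ccccc5c4)cc32)cc1` likewise gives only the limit, > 40000 nM, in this assay. Compound 2 thus stands at the limit of > 40000 nM in this assay, at which 2 of the 2 values shown sit, with no numerical value of its own. Compound 3 `COc1cccc(N2C(=O)COc3ccc(-c4cnc5ccccc5c4)cc32)c1` differs from compound 2 by 3-methoxyphenyl in place of 4-methylphenyl on an amide-type nitrogen in a ring. For the measured compounds named here, no measured step between compounds is available for comparison. The step expected in this assay, a number no higher from compound 2 to compound 3 (the limit leaves the size open), is none beyond the usual scatter, and compound 3 most likely also returns only a limit. Compound 3 is accordingly estimated at 40000 nM, within a range from 15000 nM to 100000 nM.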

Compound 3, half-maximal inhibitory concentration: > 40000 nM
Compound 3: a limit, no number (the forecaster's own chance of this, stated with the estimate: 85%); the middle value lies on the limit itself.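

Compound 2 and compound 3 both return only a limit, so no step can be read between them. The compounds shown leave open how strongly any of them inhibits, and whether 3-methoxyphenyl in place of 4-methylphenyl changes that.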